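The compounds below may be only part of what the source reports. "The series", "measured", "known", "first", "only" and "open" are said of these compounds alone.

Measured so far:
compound 1, `O=C(O)c1cc(C2=C(c3cc(Cl)ccc3OCc3ccccc3)CCC2)ncn1`: 200 nM
compound 2, `O=C(O)c1cnnc(C2=C(c3cc(Cl)ccc3OCc3ccc(F)cc3F)CCC2)c1`: 6.31 nM

Among the compounds with values here, compound 1 has the highest number of the two in an assay on isolated protein for inhibition of prostaglandin E2 receptor EP1 subtype (Homo sapiens); on this read-out higher numbers stand for weaker inhibition and lower numbers for stronger inhibition; in this assay compound 2 gives 6.31 nM, a lower number that lies beyond the scatter, and compound 2 differs from compound 1 in more than one place, so the two values show only that a pyridazine-bearing analogue can reach a much lower number. Compound 3, `O=C(O)c1cc(C2=C(c3cc(Cl)ccc3OCc3ccccc3)CCC2)cnn1`, differs from compound 1 in a single place: 6-carboxypyridazin-4-yl in place of 6-carboxypyrimidin-4-yl on a double-bonded ring carbon. Within the data shown here, no measured pair shows this change on its own. The available numbers give no direct guide to its size or direction, and a step from compound 1 to compound 3 that stays within the scatter is as plausible as a modest move to a lower number. He expects the step from compound 1 to compound 3 to be a 1.8-fold lower number from compound 1 to compound 3 (0.26 log units; within the scatter). Compound 3 is estimated at 110 nM, between 30 nM and 400 nM.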

Compound 3, half-maximal inhibitory concentration in the prostaglandin E2 receptor EP1 subtype assay: 39.8 nM
For compound 3 the middle estimate is 2.8-fold (0.44 log units) above the measured one, and the stated range covers the measured number.
By their numbers in the prostaglandin E2 receptor EP1 subtype assay, from the lowest: compound 2; then compound 3; then compound 1.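

In the prostaglandin E2 receptor EP1 subtype assay putting 6-carboxypyridazin-4-yl in place of 6-carboxypyrimidin-4-yl on the double-bonded ring carbon gives a 5.0-fold lower number from compound 1 to compound 3 (0.70 log units; beyond the scatter) as a step beyond the scatter. Within the data shown here, this is the first reading of this change on its own, since the earlier pair differed in more than one place, and it shows that the read-out at this position responds to how the same atoms are joined within the group. No measurement at hand accounts for the step.

In a physicochemical assay for lipophilicity (a higher number here means a more lipophilic compound, a lower number a more polar compound), compound 1 gives 1.2 but compound 3 gives "not determined" (no result reported) and has no reported result, so no step can be read on that measure. The compounds shown also leave open how this position would respond to an amide in place of the carboxylic acid on either group.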